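The compounds below may be only part of what the source reports. "The series", "measured", "known", "first", "only" and "open" are said of these compounds alone.

Measured so far in a functional assay on A549 cells (Homo sapiens) for inhibition, read by CCK-8 assay, with a stated time of 72 h, tested at 1 uM; on this read-out higher numbers stand for more inhibition of growth at the one concentration tested and lower numbers for less inhibition of growth:

- compound 1 `CN(C)C(=O)c1cc2cnc(Nc3ccc(NC(=O)C4(C(=O)Nc5ccc(Cl)cc5)CC4)cc3)nc2n1C1CCCC1`: 24.7%
- compound 2 `CN(C)C(=O)c1cc2cnc(Nc3ccc(NC(=O)C4(C(=O)Nc5cccc(Cl)c5)CC4)cc3)nc2n1C1CCCC1`: 8.3%
- compound 3 `COc1cccc(NC(=O)C2(C(=O)Nc3ccc(Nc4ncc5cc(C(=O)N(C)C)n(C6CCCC6)c5n4)cc3)CC2)c1`: 77.2%

These three compounds share one core and differ only in the aryl group on the far amide. Compound 3 stands highest of the three, and its gaps to both others lie beyond the scatter.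

The next compound is compound 4 `CN(C)C(=O)c1cc2cnc(Nc3ccc(NC(=O)C4(C(=O)Nc5ccc(C(F)(F)F)cc5)CC4)cc3)nc2n1C1CCCC1`. It is made from compound 3 by a single change, 4-(trifluoromethyl)phenyl in place of 3-methoxyphenyl on an amide-type nitrogen.

Among the compounds with values here, no measured compound carries a trifluoromethyl group, so any forecast is an inference from neighbours. The closest is compound 1, whose 4-chlorophenyl has the same name pattern as the incoming group. The large a number 52.5 percentage points higher from compound 1 to compound 3 (beyond the scatter) shows how much was gained on reaching the 3-methoxyphenyl group, and a number 68.9 percentage points higher from compound 2 to compound 3 (beyond the scatter) is larger still. Between the two chlorinated compounds, the step is only modest: a number 16.4 percentage points lower from compound 1 to compound 2 (beyond the scatter). Within the data shown here, compound 3 is the only methoxy example, so this trend rests on very few data.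

Leaving the methoxy group is therefore expected to give up most of that gain, and the expected change is a number 49.2 percentage points lower from compound 3 to compound 4 (beyond the scatter), a large fall. For compound 4 the estimated value in this assay is 28%, with an expected range from 8% to 58%.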

Compound 4, percent growth inhibition at one concentration: -25.3%
Compound 4: middle estimate off by 53.3 percentage points, on the high side; measured number below the stated range.
By their numbers in this assay, from the lowest: compound 4; then compound 2; then compound 1; then compound 3.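

In this assay compound 4 gives -25.3%, a number under zero, so the aryl group on this amide-type nitrogen can do more than bring the read-out close to zero, as the 3-chlorophenyl group of compound 2 did. Exchanging the 4-chlorophenyl group for 4-(trifluoromethyl)phenyl, a change to a single group, gives a number 50 percentage points lower from compound 1 to compound 4 (beyond the scatter); the comparison with the 3-chlorophenyl group gives a number 33.6 percentage points lower from compound 2 to compound 4 (beyond the scatter), and leaving the 3-methoxyphenyl group gives a number 102.5 percentage points lower from compound 3 to compound 4 (beyond the scatter), so 4-(trifluoromethyl)phenyl sits under all three other aryl groups at this one concentration. No measurement at hand explains why this group behaves so differently from the others.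

Within the data shown here, the four compounds cannot separate the identity of a group from where it sits on the ring, since the only methoxy example is 3-methoxyphenyl and the only trifluoromethyl example is 4-(trifluoromethyl)phenyl. Matching partners such as 4-methoxyphenyl and 3-(trifluoromethyl)phenyl would address that, and an unsubstituted phenyl or a 3-aminophenyl group would show how the read-out responds to other groups at this place.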